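Ethyl to isopropyl on a shared core

This account rests on a few compounds, and the source may have more. Where it says the series, first, only, none or still open, it means among the compounds named here.

Measured so far:
Compound 1, `CCc1nc(C)c2cnnc(S)n12`, in a functional assay for inhibition, with Homo sapiens as the target (on this read-out lower numbers stand for stronger inhibition and higher numbers for weaker inhibition), reaches only the limit of the assay, > 48000 nM.
Compound 2, `CCc1nc(C)c2cnnc(SC)n12`, in this assay likewise gives only a limit, > 48000 nM.

Compound 2 therefore stands at the edge of what the assay can report, with no number of its own. Going by the values given here, the single measured step, a step that the two limits leave unreadable from compound 1 to compound 2, joins two limits and so cannot be read, since both values sit at the limit of > 48000 nM in this assay, at which 2 of the 2 values shown sit. Compound 3, `CSc1nncc2c(C)nc(C(C)C)n12`, differs from compound 2 by methyl in place of hydrogen on a saturated chain carbon bound to an aromatic carbon and a saturated chain carbon. Among the compounds with values here, no measured step touches this place, and the one step known is unreadable, so there is nothing to suggest a change in this assay beyond the scatter. Compound 3 is expected to remain at or near the limit, and its estimated step from compound 2 is a step that the limit leaves unreadable from compound 2 to compound 3. Compound 3 is estimated at 60000 nM, with a range from 20000 nM to 200000 nM.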

Compound 3, half-maximal inhibitory concentration: > 48000 nM
Compound 3 was reported as a limit; the forecaster's own chance of this, stated with the estimate: 85%; the middle value does not contradict the limit.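

Compound 2 and compound 3 both give only a limit in this assay, so the step from ethyl to isopropyl cannot be read: the limit of > 48000 nM in this assay, at which 3 of the 3 values shown sit.

The compounds shown leave open whether any compound on the shared core reaches a measurable value, and how ethyl or isopropyl bears on inhibition.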